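Third methoxy on the core-attached aryl of compound 2

The source may hold more compounds than are shown below. What is called first, only, known or untested is meant among the compounds shown, and "the series" means these compounds.

Measured so far in this series:
compound 1 `COc1cc(C(=O)/C=C/c2cc(-c3cc(OC)c(OC)c(OC)c3)n3nc(-c4ccccc4)cc3n2)cc(OC)c1OC` gives 20500 nM
compound 2 `COc1ccc(C(=O)/C=C/c2cc(-c3ccc(OC)c(OC)c3)n3nc(-c4ccccc4)cc3n2)cc1OC` gives 3900 nM

In a functional assay on A549 cells (Homo sapiens) for antiproliferative activity, read by MTT assay, with a stated time of 24 h (on this read-out lower numbers stand for stronger inhibition and higher numbers for weaker inhibition), compound 2 stands lowest of the two numbers; the nearest is compound 1, whose number lies higher by a gap beyond the scatter. Compound 1 and compound 2 differ in more than one place, so the gap between them cannot be assigned to any single change.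

Compound 3 `COc1ccc(C(=O)/C=C/c2cc(-c3cc(OC)c(OC)c(OC)c3)n3nc(-c4ccccc4)cc3n2)cc1OC` is still to be measured. Relative to compound 2 it carries methoxy in place of hydrogen on an aromatic carbon, that is, methoxy in place of hydrogen on an aromatic carbon. Cut one bond further out, the aryl on the shared core goes from 3,4-dimethoxyphenyl to 3,4,5-trimethoxyphenyl, which is the pattern compound 1 carries on both aryls, while compound 3 keeps the 3,4-dimethoxyphenyl of compound 2 on the enone side.

Because compound 1 gives 20500 nM with two trimethoxyphenyls and compound 2 gives 3900 nM with two dimethoxyphenyls, compound 3, holding one of each, is expected to fall between them, with a step of a 2.1-fold higher number from compound 2 to compound 3 (0.31 log units; beyond the scatter) toward a higher number. Compound 3 is therefore estimated at 8000 nM, within 3000 nM to 22000 nM, pending the measurement.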

Compound 3, half-maximal inhibitory concentration: 17800 nM
Compound 3: middle estimate off by 2.2-fold (0.35 log units), on the low side; low and high end bracket the measured number.
By their numbers in this assay, from the lowest: compound 2; then compounds 3 and 1 (each within the scatter of the next).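

In this assay, methoxy in place of hydrogen on an aromatic carbon of the core-attached aryl, which turns 3,4-dimethoxyphenyl into 3,4,5-trimethoxyphenyl, gives a 4.6-fold higher number from compound 2 to compound 3 (0.66 log units; beyond the scatter) with the enone-side 3,4-dimethoxyphenyl held constant, so this position responds to the added group and the change does not favour inhibition in this pair. The matching single change on the enone-side aryl, read from the trimethoxyphenyl to the dimethoxyphenyl, gives a 1.2-fold lower number from compound 1 to compound 3 (0.06 log units; within the scatter) and shows no measurable response to that methoxy with the core-attached 3,4,5-trimethoxyphenyl in place. Going by these compounds alone, of the two single changes now readable, only the one on the core-attached aryl lies beyond the scatter, a distinction that the earlier pair, differing in more than one place, could not provide.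

No independent measurement is available to explain the response at the core-attached aryl. On these data alone, whether a hydroxy group, a fluorine atom or an amine at this same place would read like hydrogen or like methoxy remains open, as does whether the enone-side result holds with a 3,4-dimethoxyphenyl on the core.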